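The source may report more compounds than this note shows. Statements on the series, on what has been measured and on what is new or still open speak of the compounds shown alone.

Series notes. Compound 1 `Cn1nc(-c2cccnc2)c2ccccc2c1=O` carries hydrogen on a saturated chain carbon bound to an aromatic nitrogen. Among the measured compounds shown here, in an assay on isolated protein (Oryctolagus cuniculus) with Thromboxane-A synthase (Homo sapiens) as the target, tested at 1 uM (a higher number here means more inhibition at the concentration tested (going by the name of the read-out), a lower number less inhibition), compound 1 gives 63%, the lowest of the three numbers measured so far. Compound 2 `CC(C)=CCn1nc(-c2cccnc2)c2ccccc2c1=O` gives 94% in this assay, and compound 3 `O=c1c2ccccc2c(-c2cccnc2)nn1CC1CCCCC1` gives 98%. Both steps away from compound 1 are large and upward: a number 31 percentage points higher from compound 1 to compound 2 (beyond the scatter), and a number 35 percentage points higher from compound 1 to compound 3 (beyond the scatter). Between the two substituted compounds the step is a number 4 percentage points higher from compound 2 to compound 3 (within the scatter).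

Compound 4 `CC(=O)Cn1nc(-c2cccnc2)c2ccccc2c1=O` differs from compound 1 by acetyl in place of hydrogen on a saturated chain carbon bound to an aromatic nitrogen. The two measured steps from compound 1 bear on this change, since each also replaces hydrogen at the same place, and both were large. The group entering in compound 4 carries one hydrogen-bond acceptor and no ring, which neither of the measured groups does, so the step is expected to be upward but somewhat smaller than those two. The expected step is a number 17 percentage points higher from compound 1 to compound 4 (beyond the scatter). Compound 4 is estimated at 80% in this assay, with a range from 62% to 94%.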

Compound 4, a percentage reported as inhibition, at one concentration (the size of the read-out at that concentration, not a potency): 13%
Beside the measured number, compound 4's estimate is 67 percentage points above it, outside the stated range (below it).
By their numbers in this assay, from the lowest: compound 4; then compound 1; then compounds 2 and 3 (each within the scatter of the next).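

The place does not reward every group put in for hydrogen: in this assay the change to acetyl runs against the two earlier upward steps (a number 50 percentage points lower from compound 1 to compound 4 (beyond the scatter)), so even the direction of a step here depends on the entering group. Measured against the groups already at this place, acetyl stands far lower (a number 85 percentage points lower from compound 3 to compound 4 (beyond the scatter); a number 81 percentage points lower from compound 2 to compound 4 (beyond the scatter)), so a change on this one carbon spans nearly the whole spread of the series. No measurement in hand accounts for this reversal or ties it to any feature of acetyl.

As far as these compounds go, whether the fall follows the carbonyl or the short chain stays open. A plain propyl, a 2-hydroxypropyl, or a chain ending in an amine or a carboxylic acid at this place would help separate those readings.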